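The compounds below may be only part of what the source reports. "The series", "measured", "known", "first", "only" and "open" are said of these compounds alone.

Measured so far:
Compound 1 `O=C(NOCc1ccc(Cl)cc1Cl)c1cn(-c2ccccc2)nc1-c1ccc(Cl)cc1`: 13100 nM
Compound 2 `O=C(NOCc1ccccc1F)c1cn(-c2ccccc2)nc1-c1ccc(F)cc1`: 17500 nM
Compound 3 `O=C(NOCc1ccccc1Cl)c1cn(-c2ccccc2)nc1-c1ccc(F)cc1`: 8330 nM

In a functional assay on A549 cells (Homo sapiens) for antiproliferative activity, read by MTT assay, with a stated time of 48 h, in the presence of a further agent that is not named here (on this read-out lower numbers stand for stronger inhibition of growth and higher numbers for weaker inhibition of growth), compound 3 gives the lowest of these three numbers; compound 1 stands within the scatter of it, compound 2 beyond it. Compound 4 `O=C(NOCc1ccc(Cl)cc1Cl)c1cn(-c2ccccc2)nc1-c1ccc(F)cc1` differs from compound 3 by chloro in place of hydrogen on an aromatic carbon, turning a (2-chlorobenzyl)oxy group into a (2,4-dichlorobenzyl)oxy group. Among the measured compounds shown here, the only measured step, a 2.1-fold lower number from compound 2 to compound 3 (0.32 log units; beyond the scatter), concerns a different change and does not bear on this one. Compound 1 carries the same 2,4-dichlorobenzyl group but differs from compound 3 in a second place as well, so its value and that of compound 3 can only be set side by side. The step from compound 3 to compound 4 is therefore expected to be small, a 1.2-fold higher number from compound 3 to compound 4 (0.08 log units; within the scatter), with no clear direction. Compound 4 is estimated at 10000 nM, between 5000 nM and 22000 nM.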

Compound 4, concentration for 50% growth inhibition: 14000 nM
Compound 4: middle estimate off by 1.4-fold (0.15 log units), on the low side; the range from low to high includes it.
By their numbers in this assay, from the lowest: compounds 3, 1, 4 and 2 (each within the scatter of the next, the first and the last beyond it).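

Turning the (2-chlorobenzyl)oxy group into the (2,4-dichlorobenzyl)oxy group gives a 1.7-fold higher number from compound 3 to compound 4 (0.23 log units; within the scatter), so in this assay this added chloro, para to a large group, brings no readable change. Replacing the whole 2-fluorophenyl with 2,4-dichlorophenyl also gives only a 1.3-fold lower number from compound 2 to compound 4 (0.10 log units; within the scatter), while fluoro in place of chloro on an aromatic carbon gives a 1.1-fold higher number from compound 1 to compound 4 (0.03 log units; within the scatter). The exchange between chloro and fluoro reads alike on both cores, as far as the scatter allows: the same change on two cores in this assay, a 2.1-fold lower number (0.32 log units; beyond the scatter) from compound 2 to compound 3 and a 1.1-fold lower number (0.03 log units; within the scatter) from compound 4 to compound 1, 2.0-fold (0.29 log units) apart, within the scatter of two such steps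

Still open, on these data alone, is whether anything other than a halogen at this position, such as a methoxy group or an amine, would shift the number beyond the scatter.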